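Estimating Compound 3 from Two Measured Compounds

This account rests on a few compounds, and the source may have more. Where it says the series, first, only, none or still open, it means among the compounds named here.

Compound 1, `Cc1cccc(-c2noc([C@H](C)NC(=O)c3cc(C(F)(F)F)nn3C)n2)n1`: in an assay on T-REx-293 cells for inhibition of potassium channel subfamily T member 1 (Homo sapiens), read by patch clamp (a higher number here means a weaker inhibitor, a lower number a stronger inhibitor), compound 1 reports only a limit, > 30000 nM.
Compound 2, `Cc1cc(-c2noc([C@H](C)NC(=O)c3cc(C(F)(F)F)nn3C)n2)ncn1`: in this assay compound 2 gives 1410 nM.

For the measured compounds named here, compound 2 holds the only number in this assay; compound 1 sits at the limit of > 30000 nM in this assay, at which 1 of the 2 values shown sits. Going by the values given here, the single measured step, an at least 21-fold lower number from compound 1 to compound 2 (1.32 log units; beyond the scatter), took the read-out from a limit to a number. Compound 3, `C[C@H](NC(=O)c1cc(C(F)(F)F)nn1C)c1nc(-c2cnn(C)c2)no1`, carries 1-methyl-1H-pyrazol-4-yl in place of 6-methylpyrimidin-4-yl on an aromatic carbon. This exchange of a five-membered aromatic ring for a six-membered one differs in kind from the measured step, which swapped one six-membered aromatic ring for another, so that step is only a loose guide. Compound 3 is therefore expected to show a 2.1-fold higher number from compound 2 to compound 3 (0.33 log units; beyond the scatter), a shift not clearly beyond the scatter, with an estimated value of 3000 nM (from 800 nM to 15000 nM).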

Compound 3, half-maximal inhibitory concentration: 2640 nM
Compound 3: the middle estimate sits 1.1-fold (0.06 log units) above what was measured, and the stated range covers the measured number.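

In this assay, 1-methyl-1H-pyrazol-4-yl in place of 6-methylpyrimidin-4-yl gives a 1.9-fold higher number from compound 2 to compound 3 (0.27 log units; within the scatter), so in these two compounds this position carries a five-membered aromatic ring as well as a six-membered one with no change beyond the scatter. Against 6-methylpyridin-2-yl, the same pyrazole gives an at least 11-fold lower number from compound 1 to compound 3 (1.05 log units; beyond the scatter), which sets compound 1 apart from both other compounds. The value of compound 1 is a limit.

The compounds shown leave open whether the methyl on the pyrazole matters, and whether an aromatic ring is needed here at all. An open chain such as butyl, or an amine, could answer the second question.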